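Trading a Methyl for Hydrogen on a Ring Nitrogen

The compounds below may be only part of what the source reports. "The series", "measured", "known", "first", "only" and "open" are said of these compounds alone.

Measured so far:
compound 1, `CC(=O)Nc1nc(-c2cccc(NS(=O)(=O)c3ccc(C#CCCc4ccccc4)cc3)c2)cs1`, in a functional assay on A-375 cells (Homo sapiens) for antiproliferative activity, read by trypan blue exclusion, with a stated time of 48 h, tested at 5 uM (on this read-out lower numbers stand for a stronger effect and higher numbers for a weaker effect at the one concentration tested), gives 4.2%
compound 2, `CCCCCCC#Cc1ccc(S(=O)(=O)Nc2cccc(-c3csc(NC)n3)c2)cc1`, in this assay gives 8.1%

Compound 2 holds the higher of the two numbers, but its gap to compound 1 lies within the scatter, so the two cannot be told apart. Compound 3, `CCCCCCC#Cc1ccc(S(=O)(=O)Nc2cccc(-c3csc(N)n3)c2)cc1`, keeps everything of compound 2 except one spot: hydrogen in place of methyl on a nitrogen on an aromatic ring. Among the compounds with values here, no step between measured compounds isolates such a change, so there is no anchor for its size. The expected step of a number 0.9 percentage points higher from compound 2 to compound 3 (within the scatter) is none beyond the scatter. Compound 3 is therefore expected to give 9%, within a range from 2% to 25%.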

Compound 3, a percentage reported as activity, at one concentration (the size of the read-out at that concentration, not a potency): < 1%
Compound 3 ended at the assay's limit; the forecaster's own chance of this, stated with the estimate: 0%; middle value at least 8 percentage points from the limit.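

In this assay compound 3 gives < 1%, which is a limit of the assay and not a number. As far as these compounds go, replacing methylamino with amino on this position gives a number at least 7.1 percentage points lower from compound 2 to compound 3 (that floor lies within the scatter), so the methyl is not needed to keep the effect in this read-out, though the true size of the step stays unknown. The result reaches the end of the scale: the limit of < 1% in this assay, at which 1 of the 3 values shown sits.

Still open, from the compounds shown here alone, is what an ethyl group or a longer chain on this nitrogen would do.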